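The compounds below may be only part of what the source reports. "The series", "measured", "known", "first", "only" and "open" are said of these compounds alone.

Measured so far in a functional assay on HeLa cells (Homo sapiens) for antiproliferative activity, with a stated time of 24 h; a lower number here means a stronger inhibitor, a higher number a weaker inhibitor:
compound 1 `Cc1ccccc1NC(=S)N1CCc2c(sc(NC(=O)c3ccccc3Cl)c2C(N)=O)C1` gives > 50000 nM, which is a limit of the assay and not a number.
compound 2 `NC(=O)c1c(NC(=O)c2ccccc2Cl)sc2c1CCN(C(=S)Nc1cccnc1)C2` gives > 50000 nM, again a limit of the assay.

Compound 1 therefore stands only at a limit of this assay; no number places it within the measurable range. Compound 2 stands at the same kind of limit. The step that the two limits leave unreadable from compound 1 to compound 2 accordingly cannot be read, since both values sit at the limit of > 50000 nM in this assay, at which 2 of the 2 values shown sit.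

Compound 3 `Cc1ccccc1NC(=S)N1CCc2c(sc(NC(=O)c3ccccc3Br)c2C(N)=O)C1` differs from compound 1 by bromo in place of chloro on an aromatic carbon. Going by the values given here, no measured step involves this exchange, and the single measured step, at another position of the shared core, is itself unreadable. With compound 1 at a limit, compound 3 is expected to remain at that limit as well, the step that the limit leaves unreadable from compound 1 to compound 3 being an estimate without measured support. The estimate for compound 3 in this assay is 60000 nM, with a range from 20000 nM to 200000 nM.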

Compound 3, half-maximal inhibitory concentration: > 50000 nM
Compound 3: only a limit was reported (the forecaster's own chance of this, stated with the estimate: 85%); the middle value is on the limit's open side.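

Compound 1 and compound 3 both stand at a limit of the assay and not at a number, so no new step can be read from this pair: the limit of > 50000 nM in this assay, at which 3 of the 3 values shown sit.

The compounds shown leave open which change to the shared core, if any, brings a value into the measurable range.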